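This account rests on a few compounds, and the source may have more. Where it says the series, first, only, none or still open, it means among the compounds named here.

Measured compounds:
compound 1, `CC(C)Oc1cc(-c2cncc(-c3cnn(C)c3)c2)ccc1C(N)=O`, 160 nM
compound 2, `Cc1n[nH]c(C)c1-c1cncc(-c2ccc(C(N)=O)c(OC(C)C)c2)c1`, 14 nM

Compound 2 holds the lowest number of the two in an assay on cells for inhibition of MAP kinase-interacting serine/threonine-protein kinase 2 (Homo sapiens), read by mobility shift assay, with stated times of 10 min and 60 min, in the presence of a further agent that is not named here; a higher number here means a weaker inhibitor, a lower number a stronger inhibitor; its nearest neighbour is compound 1, reached by an 11-fold lower number from compound 1 to compound 2 (1.06 log units; beyond the scatter), a step well beyond the scatter and tied solely to the exchange of 1-methyl-1H-pyrazol-4-yl for 3,5-dimethyl-1H-pyrazol-4-yl on an aromatic carbon of the shared core.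

Compound 3, `CC(C)Oc1cc(-c2cncc(-c3cnn(C(C)C)c3)c2)ccc1C(N)=O`, has not yet been measured in this assay. It differs from compound 2 in one place: 1-isopropyl-1H-pyrazol-4-yl in place of 3,5-dimethyl-1H-pyrazol-4-yl on an aromatic carbon. Compound 3 therefore carries a 1-isopropyl-1H-pyrazol-4-yl group, which resembles the 1-methyl-1H-pyrazol-4-yl group of compound 1 more than the 3,5-dimethyl-1H-pyrazol-4-yl group of compound 2. Among the measured compounds shown here, the only step that bears on this change, the one from compound 1 to compound 2, was large, and reversing most of that change is expected to raise the number again, so compound 3 is expected to show a 9.3-fold higher number from compound 2 to compound 3 (0.97 log units; beyond the scatter). Compound 3 is thus estimated at 130 nM, within a range of 40 nM to 400 nM, near the value of compound 1.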

Compound 3, half-maximal inhibitory concentration: 42 nM
Compound 3: the middle estimate sits 3.1-fold (0.49 log units) above what was measured, within the range that was stated.
By their numbers in this assay, from the lowest: compound 2; then compound 3; then compound 1.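

Within this assay, the group on this aromatic carbon responds to a change at its aromatic nitrogen alone: isopropyl in place of methyl gives a 3.8-fold lower number from compound 1 to compound 3 (0.58 log units; beyond the scatter), so part of the gain seen with compound 2 is reached without the two ring methyl groups of 3,5-dimethyl-1H-pyrazol-4-yl. The exchange of that group for 1-isopropyl-1H-pyrazol-4-yl still costs something, with a 3.0-fold higher number from compound 2 to compound 3 (0.48 log units; beyond the scatter), yet it shows that a group with 0 hydrogen-bond donors can stay within a modest step of the one with 1 hydrogen-bond donor. Nothing measured here explains either change.

The compounds shown leave open whether a longer chain or a cyclopropyl group on that aromatic nitrogen would lower the number further. They also leave open how an isopropyl on that nitrogen would behave together with the two ring methyl groups.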